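The source may report more compounds than this note shows. Statements on the series, on what has been measured and on what is new or still open speak of the compounds shown alone.

Compound 1 `CSc1ccccc1NC(=O)N[C@H]1CC[C@H](Oc2ccc(F)cc2)CC1`: in a functional assay on CRL2813 cells (Homo sapiens) for cytotoxicity, read by sulforhodamine B assay, with a stated time of 5 days (a higher number here means a weaker inhibitor, a lower number a stronger inhibitor), compound 1 gives > 20000 nM, which is a limit of the assay and not a number.
Compound 2 `O=C(Nc1ccccc1[N+](=O)[O-])N[C@H]1CC[C@H](Oc2ccc(F)cc2)CC1`: in this assay compound 2 gives 3500 nM.
Compound 3 `O=C(Nc1ccccc1Br)N[C@H]1CC[C@H](Oc2ccc(F)cc2)CC1`: in this assay compound 3 gives 7700 nM.

Among the measured compounds shown here, of the two numbers measured, compound 3 stands highest; the only other number shows a 2.2-fold higher number from compound 2 to compound 3 (0.34 log units; beyond the scatter). Compound 1 sits at the limit of > 20000 nM in this assay, at which 1 of the 3 values shown sits, so its distance from the others is known only as a bound, an at least 2.5-fold lower number from compound 1 to compound 3 (0.41 log units; beyond the scatter) and an at least 5.7-fold lower number from compound 1 to compound 2 (0.75 log units; beyond the scatter).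

Compound 4 `O=C(Nc1ccccc1OC(F)(F)F)N[C@H]1CC[C@H](Oc2ccc(F)cc2)CC1` differs from compound 3 in one place: trifluoromethoxy in place of bromo on an aromatic carbon. All three measured steps exchange the group on this same aromatic carbon, and each of them was modest, at least in the bounded cases. The three groups measured there span from a limit to the number of compound 2, so another exchange at this position is expected to move this assay by a modest amount at most, with the direction uncertain and a step beyond the scatter possible in either sense. Compound 4 is therefore estimated at 9000 nM, within 3000 nM to 30000 nM, meaning an expected step of a 1.2-fold higher number from compound 3 to compound 4 (0.07 log units; within the scatter).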

Compound 4, half-maximal inhibitory concentration: > 20000 nM
Compound 4: no number, only a limit; the forecaster's own chance of this, stated with the estimate: 25%; at least 2.2-fold (0.34 log units) between middle value and limit.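

In this assay compound 4 gives > 20000 nM as a limit of the assay and not a number. Among the compounds shown here, the exchange of bromo for trifluoromethoxy gives an at least 2.5-fold higher number from compound 3 to compound 4 (0.41 log units; beyond the scatter) and the exchange of nitro for trifluoromethoxy gives an at least 5.7-fold higher number from compound 2 to compound 4 (0.75 log units; beyond the scatter) so this new group moves the reading the same way from both compounds that have numbers, a direction the earlier compounds gave no way to foresee for it. Trifluoromethoxy thus joins methylsulfanyl at the limit, the step between those two compounds cannot be read, and on this aromatic carbon only nitro and bromo so far give numbers: the limit of > 20000 nM in this assay, at which 2 of the 4 values shown sit.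

On these data alone, how far compound 1 and compound 4 actually lie beyond the limit stays open, so their order relative to each other is unknown. Also open, as far as these compounds go, is whether an amine or a carboxylic acid on this aromatic carbon would give a lower number than compound 2 does, and what a longer chain elsewhere on the shared core would do.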